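From Methoxy to (3,4,5-Trihydroxy-6-methyloxan-2-yl)oxy: Compound 3

The source may hold more compounds than are shown below. What is called first, only, known or untested is meant among the compounds shown, and "the series" means these compounds.

Measured compounds:
Compound 1, `CSC(=O)c1c(O[C@@H]2O[C@@H](C)[C@H](O)[C@@H](O)[C@H]2O)c(C)c(O)c(C)c1C(C)C` — 44%
Compound 2, `COc1c(C)c(O[C@@H]2O[C@@H](C)[C@H](O)[C@@H](O)[C@H]2O)c(C(=O)SC)c(C(C)C)c1C` — 47%

In a functional assay (Mesenchymal stem cell, Homo sapiens) for activation, read by ELISA, with a stated time of 6 days (a higher number here means a larger maximal response, a lower number a smaller maximal response), compound 2 gives 47%, and compound 1 gives 44%. Within the data shown here, the single measured step between them is a number 3 percentage points higher from compound 1 to compound 2 (within the scatter), so the two values lie within the scatter of each other and neither can be called larger in this assay.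

Compound 3, `CSC(=O)c1c(O[C@@H]2O[C@@H](C)[C@H](O)[C@@H](O)[C@H]2O)c(C)c(O[C@@H]2O[C@@H](C)[C@H](O)[C@@H](O)[C@H]2O)c(C)c1C(C)C`, differs from compound 2 in one place: 3,4,5-trihydroxy-6-methyloxan-2-yl in place of methyl on an oxygen on an aromatic ring. Among the measured compounds shown here, the only measured step bears on the same oxygen on the aromatic ring, where hydrogen gave way to methyl without a change beyond the scatter. Nothing measured here shows what a 3,4,5-trihydroxy-6-methyloxan-2-yl group does on that oxygen, so the expectation rests on that one step alone, and the range has to be wide.

Compound 3 is therefore expected to give 45% in this assay, with a range from 28% to 62%. The expected step is a number 2 percentage points lower from compound 2 to compound 3 (within the scatter), which is not expected to exceed the scatter.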

Compound 3, largest response reached (reported as percent of maximum), in percent of the reference or control that the assay uses: 38%
Compound 3: the middle estimate sits 7 percentage points above what was measured; the measured number falls inside the stated range.
By their numbers in this assay, from the lowest: compounds 3, 1 and 2 (each within the scatter of the next).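

Among these compounds, on the oxygen on an aromatic ring, the earlier compounds offered only hydrogen and methyl, and compound 3 extends that comparison to a far larger substituent, 3,4,5-trihydroxy-6-methyloxan-2-yl, with 10 heavy atoms and one six-membered non-aromatic ring. In this assay, exchanging methyl for this group gives a number 9 percentage points lower from compound 2 to compound 3 (within the scatter), and exchanging hydrogen for it gives a number 6 percentage points lower from compound 1 to compound 3 (within the scatter), so the maximal response at this position cannot be told apart across all three substituents, despite the large difference in size between them. No independent measurement offers an explanation for this result.

The compounds shown leave open whether a group of another kind on this oxygen, such as a carboxylic acid, an amine or a longer alkyl chain, would shift the response in this assay beyond the scatter. All three compounds also carry a 3,4,5-trihydroxy-6-methyloxan-2-yl group on a second oxygen of the shared core, and what that group contributes to the response remains an open question.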